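The compounds below may be only part of what the source reports. "The series", "measured", "known", "first", "only" and "open" are said of these compounds alone.

Compound 1, `Cc1cc(C)cc(Oc2ccc3nc(COc4cccc(C(=O)O)c4)n(C)c3n2)c1`: 17.4 10^-6 cm/s
Compound 2, `Cn1c(COc2cccc(C(=O)O)c2)nc2cnc(Oc3ccc4c(c3)OCC4)cc21`: 3.6 10^-6 cm/s
Compound 3, `Cn1c(COc2cccc(C(=O)O)c2)nc2ccc(Oc3ccccn3)cc21`: 2.2 10^-6 cm/s

These three numbers come from an ADME assay for permeability, using PAMPA, with a stated time of 4 h; a lower number here means that the compound crosses the layer more slowly, a higher number that the compound crosses the layer faster. Compound 3 has the lowest of them. The nearest is compound 2, whose value lies within the usual scatter of compound 3, so the two cannot be ordered. Compound 1 stands furthest away, its number beyond the scatter relative to compound 3. No two of the measured compounds differ in only one place, so no single step can be read from the values on hand.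

Compound 4, `Cn1c(COc2cccc(C(=O)O)c2)nc2ccc(Oc3ccc(F)cn3)cc21`, has not yet been measured in this assay. It differs from compound 3 in one place: fluoro in place of hydrogen on an aromatic carbon. Within the data shown here, there is no measured pair that shows what such a change does here, so nothing beyond general experience can guide the guess. A small step is expected, a 1.4-fold higher number from compound 3 to compound 4 (0.13 log units; within the scatter), in either direction no larger than the scatter. Compound 4 is expected to give 3 10^-6 cm/s, with a range from 1.5 10^-6 cm/s to 6 10^-6 cm/s.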

Compound 4, apparent permeability: 4.7 10^-6 cm/s
For compound 4 the middle estimate is 1.6-fold (0.19 log units) below the measured one; the measured number falls inside the stated range.
By their numbers in this assay, from the lowest: compounds 3, 2 and 4 (each within the scatter of the next, the first and the last beyond it); then compound 1.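

In this assay, among these compounds, the change from (pyridin-2-yl)oxy to (5-fluoropyridin-2-yl)oxy provides the first single-place step in this set, a 2.1-fold higher number from compound 3 to compound 4 (0.33 log units; beyond the scatter). Among the compounds shown here, it shows that fluoro in place of hydrogen on this aromatic carbon, two atoms from the ring nitrogen and para to a large group, gives a modest change beyond the scatter, which the earlier compounds, differing in more than one place, could not show. Nothing measured here accounts for this step.

From the compounds shown here alone, whether chloro, methyl or a nitrile at the same carbon would shift the number in the same direction remains open. So does whether fluoro would have a comparable effect at another carbon of this ring, or on the cores of compound 1 and compound 2.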